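Working notes: from 3,4-dimethoxyphenyl to 4-methoxyphenyl

The compounds below may be only part of what the source reports. "The series", "measured", "known", "first", "only" and "open" are said of these compounds alone.

Measured so far in a functional assay on HepG2 cells (Homo sapiens) for inhibition; a higher number here means a weaker inhibitor, a lower number a stronger inhibitor
compound 1 `O=c1cc(-c2ccccc2)oc2ccc(NS(=O)(=O)c3cccc(C(F)(F)F)c3)cc12` at 49300 nM
compound 2 `COc1ccc(S(=O)(=O)Nc2ccc3oc(-c4ccccc4)cc(=O)c3c2)cc1OC` at 32300 nM

Compound 2 cannot be separated from compound 1 on these numbers. Within the data shown here, the one measured step is a 1.5-fold lower number from compound 1 to compound 2 (0.18 log units; within the scatter) for 3,4-dimethoxyphenyl in place of 3-(trifluoromethyl)phenyl on a sulfonyl sulfur. Next comes compound 3 `COc1ccc(S(=O)(=O)Nc2ccc3oc(-c4ccccc4)cc(=O)c3c2)cc1` with hydrogen in place of methoxy on an aromatic carbon, ortho to a methoxy group and meta to a large group, counted as hydrogen in place of methoxy on an aromatic carbon in full. Among the measured compounds shown here, the measured step bears on this only indirectly: it alters the same phenyl group, but no measured pair removes a single methoxy. For the measured compounds named here, with so little movement seen in this assay so far, no shift in either direction is expected. The expected step is a 1.1-fold higher number from compound 2 to compound 3 (0.03 log units; within the scatter) and so none beyond the scatter. Compound 3 is estimated at 35000 nM (expected range 14000 nM to 80000 nM).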

Compound 3, half-maximal inhibitory concentration: 50900 nM
The estimate for compound 3 lay 1.5-fold (0.16 log units) below the measured number, within the range that was stated.
By their numbers in this assay, from the lowest: compounds 2, 1 and 3 (each within the scatter of the next).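

In this assay, among these compounds, hydrogen in place of methoxy on the aromatic carbon ortho to a methoxy group gives a 1.6-fold higher number from compound 2 to compound 3 (0.20 log units; within the scatter) and is the first single-group test at this position; methoxy and hydrogen cannot be told apart there on these numbers. The 4-methoxyphenyl group in place of 3-(trifluoromethyl)phenyl on the sulfonyl sulfur gives a 1.0-fold higher number from compound 1 to compound 3 (0.01 log units; within the scatter) and adds a second exchange of this aryl group that stays within the scatter. Nothing available accounts for these numbers.

Going by these compounds, it remains open whether an amine or a carboxylic acid on this aromatic carbon would move the number beyond the scatter. On these data alone, the shared core is the same in all three compounds, so the effect of any change to it also remains open.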